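Swapping an Amide for a Urea on a Shared Core

The source may hold more compounds than are shown below. What is called first, only, known or untested is meant among the compounds shown, and "the series" means these compounds.

Of the compounds shown here, three on one core have been measured in a functional assay on RXF 393 cells (Homo sapiens) for inhibition, read by sulforhodamine B assay, with a stated time of 48 h; on this read-out higher numbers stand for weaker inhibition of growth and lower numbers for stronger inhibition of growth: compound 1 `O=C(Nc1cccc(-n2cc(-c3ccncc3)c(-c3ccc(Cl)c(O)c3)n2)c1)Nc1ccc(Cl)c(Cl)c1`, compound 2 `COc1cc(-c2nn(-c3cccc(NC(=O)c4ccc(Cl)c(C(F)(F)F)c4)c3)cc2-c2ccncc2)ccc1Cl` and compound 3 `COc1cc(-c2nn(-c3cccc(NC(=O)Nc4cccc(C(F)(F)F)c4)c3)cc2-c2ccncc2)ccc1Cl`. Compound 2 gives 18700 nM, the highest number of the three; compound 1 gives 6400 nM and compound 3 gives 1940 nM. Compound 4 `COc1cc(-c2nn(-c3cccc(NC(=O)Nc4ccc(Cl)c(C(F)(F)F)c4)c3)cc2-c2ccncc2)ccc1Cl` awaits measurement, and it differs from compound 2 as follows: (4-chloro-3-(trifluoromethyl)phenyl)amino in place of 4-chloro-3-(trifluoromethyl)phenyl on a carbonyl carbon. Going by the values given here, the one measured step that bears on this is a 9.6-fold lower number from compound 2 to compound 3 (0.98 log units; beyond the scatter), though that step also altered the aryl group, so it is only a partial guide. A lower number is therefore expected for compound 4, probably a smaller step than that one. Compound 4 is estimated at 4500 nM, in a range from 1500 nM to 13000 nM, an expected step of a 4.2-fold lower number from compound 2 to compound 4 (0.62 log units; beyond the scatter).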

Compound 4, concentration for total growth inhibition: 6290 nM
Estimate against measurement, compound 4: 1.4-fold (0.15 log units) below; low and high end bracket the measured number.
By their numbers in this assay, from the lowest: compound 3; then compounds 4 and 1 (each within the scatter of the next); then compound 2.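

With the 4-chloro-3-(trifluoromethyl)phenyl group held fixed, the urea in place of the amide alone gives a 3.0-fold lower number from compound 2 to compound 4 (0.47 log units; beyond the scatter) in this assay, so the earlier drop did not depend on losing the chloro. Within the ureas, chloro in place of hydrogen on an aromatic carbon gives a 3.2-fold higher number from compound 3 to compound 4 (0.51 log units; beyond the scatter) and thus takes back part of the gain. Nothing available explains either shift. Still open, going by these compounds, is whether a fluoro or a nitrile in place of that chloro would keep the lower number, or whether a longer chain on the carbonyl carbon would match the urea.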